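Swapping the Chain Terminus: From Compound 2 to Compound 3

This account rests on a few compounds, and the source may have more. Where it says the series, first, only, none or still open, it means among the compounds named here.

Measured so far:
Compound 1, `c1cnc2c(c1)CCC[C@@H]2N(CCCN1CCNCC1)Cc1cc2ccccc2cn1`: 66%
Compound 2, `c1ccc2c(c1)CN[C@@H](CN(CCC1CCNCC1)[C@H]1CCCc3cccnc31)C2`: 66%

In an ADME assay on microsomes from liver (Homo sapiens) for metabolic stability, read by LC-MS, with a stated time of 10 min, tested at 0.5 uM (on this read-out higher numbers stand for a more stable compound and lower numbers for a less stable compound), compound 1 gives 66%. In this assay compound 2 gives 66%, which is level with compound 1 within the usual scatter of this measurement. Among the compounds with values here, compounds 1 and 2 differ in more than one place, so no single-change step joins them, and only their two values can be set side by side.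

Compound 3 `c1ccc2c(c1)CN[C@@H](CN(CCCN1CCNCC1)[C@H]1CCCc3cccnc31)C2` has not yet been measured. It differs from compound 2 in one place: (piperazin-1-yl)methyl in place of piperidin-4-yl on a saturated chain carbon, two bonds along the chain from an amine nitrogen. The group that enters is the same one that compound 1 carries on its own chain, and in this assay compound 1 stands where compound 2 stands. Within the data shown here, with no single-change step recorded, the step of a number 2 percentage points lower from compound 2 to compound 3 (within the scatter) is expected to be small, in no fixed direction, and not beyond the scatter. Compound 3 is therefore estimated at 64%, with a range from 45% to 82%.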

Compound 3, percent of the compound remaining: 100%
For compound 3 the middle estimate is 36 percentage points below the measured one; measured number outside the range, above it.
By their numbers in this assay, from the lowest: compounds 1 and 2 (each within the scatter of the next); then compound 3.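

In this assay, (piperazin-1-yl)methyl in place of piperidin-4-yl gives a number 34 percentage points higher from compound 2 to compound 3 (beyond the scatter), so this chain position can matter greatly for the compound's survival in the assay. The second change, 1,2,3,4-tetrahydroisoquinolin-3-yl in place of isoquinolin-3-yl, gives a number 34 percentage points higher from compound 1 to compound 3 (beyond the scatter), which shows that the piperazine-bearing chain does not bring this gain in every setting and that the effect of each change depends on the group present at the other place. Nothing shown here gives a measured reason for this large rise.

Still open, from the compounds shown here alone, is whether the second nitrogen of the piperazine ring matters in itself or whether other rings, such as morpholine, would give a similar result. A longer chain leading to the piperazine ring could also behave differently at this position.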